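The compounds below may be only part of what the source reports. "The series", "measured", "known", "first", "only" and "open" are said of these compounds alone.

Working notes on the series, read in a functional assay on MCF7 cells (Homo sapiens) for antiproliferative activity, read by sulforhodamine B assay, with a stated time of 48 h; on this read-out lower numbers stand for stronger inhibition and higher numbers for weaker inhibition. Compound 3 `CCN1CCN(c2ccc(S(=O)(=O)Oc3cccc(F)c3)cc2)C1=O` gives > 100000 nM, which is a limit of the assay and not a number. Compound 1 `CN1CCN(c2ccc(S(=O)(=O)Oc3cccc(F)c3)cc2)C1=O` gives > 100000 nM, also a limit. The series therefore shows (the limit of > 100000 nM in this assay, at which 2 of the 3 values shown sit). Compound 2 `CN1CCN(c2ccc(S(=O)(=O)Oc3cccc(Br)c3)cc2)C1=O` gives a number, 1500 nM.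

The change to compound 4 `CCN1CCN(c2ccc(S(=O)(=O)Oc3cccc(Br)c3)cc2)C1=O` is bromo in place of fluoro on an aromatic carbon, that is, 3-fluorophenyl to 3-bromophenyl, on an aromatic carbon meta to a large group. The same exchange has been measured once, and it reads an at least 66-fold lower number from compound 1 to compound 2 (1.82 log units; beyond the scatter). The other measured step, methyl in place of hydrogen, reads a step that the two limits leave unreadable from compound 1 to compound 3, so it gives no size for that change on the bromo side. The expectation thus rests on a single pair, with compound 2 at 1500 nM as the nearest number. Expected in this assay is an at least 50-fold lower number from compound 3 to compound 4 (1.69 log units; beyond the scatter), a large step toward a lower number. Compound 4 is estimated at 2000 nM, with an expected range from 400 nM to 15000 nM.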

Compound 4, half-maximal inhibitory concentration: 2500 nM
The estimate for compound 4 lay 1.3-fold (0.10 log units) below the measured number; low and high end bracket the measured number.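

In this assay the exchange of 3-fluorophenyl to 3-bromophenyl now reads on a second core, an at least 40-fold lower number from compound 3 to compound 4 (1.60 log units; beyond the scatter), so the drop seen with the methyl compounds also appears with the ethyl compounds: the same change on two cores in this assay, an at least 66-fold lower number (1.82 log units; beyond the scatter) from compound 1 to compound 2 and an at least 40-fold lower number (1.60 log units; beyond the scatter) from compound 3 to compound 4; the limit leaves it open whether they differ

For the compounds shown here, with bromo in place, the methyl in place of hydrogen step can be read for the first time, a 1.7-fold higher number from compound 2 to compound 4 (0.22 log units; within the scatter), and so the ethyl and methyl compounds on the bromo side do not separate in this assay. The same step on the fluoro side cannot be read, both of its values being limits: the limit of > 100000 nM in this assay, at which 2 of the 4 values shown sit.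

Open, going by these compounds, is how chloro or iodo would read on this aromatic carbon, between the fluoro limit and the bromo numbers or elsewhere. Also open, on these data alone, is whether a longer chain, such as propyl, on the amide-type nitrogen would keep the number seen with compound 4.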